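Adding a second trifluoromethyl to the aryl of compound 3

The compounds below may be only part of what the source reports. "The series", "measured", "known", "first", "only" and "open" are said of these compounds alone.

Among the compounds with values here, in a functional assay on MDA-MB-231 cells (Homo sapiens) for antiproliferative activity, read by MTT assay, with a stated time of 72 h (on this read-out lower numbers stand for stronger inhibition and higher numbers for weaker inhibition), compound 3 `O=C(Nc1cccc(-c2nc(-c3ccc(NC(=O)c4cccnc4)cc3Cl)no2)c1)Nc1cccc(C(F)(F)F)c1` gives 1900 nM, the only number among the three measured compounds. Compound 1 `O=C(Nc1ccc(Cl)cc1)Nc1cccc(-c2nc(-c3ccc(NC(=O)c4cccnc4)cc3Cl)no2)c1` reaches only the limit of > 10000 nM in this assay. Compound 2 `NS(=O)(=O)c1ccc(NC(=O)Nc2cccc(-c3nc(-c4ccc(NC(=O)c5cccnc5)cc4Cl)no3)c2)cc1` likewise reaches only the limit of > 10000 nM in this assay. Within the data shown here, two steps bear on the change at hand: an at least 5.2-fold lower number from compound 1 to compound 3 (0.72 log units; beyond the scatter) and an at least 5.2-fold lower number from compound 2 to compound 3 (0.72 log units; beyond the scatter), both pointing to the 3-(trifluoromethyl)phenyl group on the amide-type nitrogen. The step that the two limits leave unreadable from compound 1 to compound 2 cannot be read because the limit of > 10000 nM in this assay, at which 2 of the 3 values shown sit, holds both values.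

Compound 4 `O=C(Nc1cccc(-c2nc(-c3ccc(NC(=O)c4cccnc4)cc3Cl)no2)c1)Nc1cc(C(F)(F)F)cc(C(F)(F)F)c1` differs from compound 3 by trifluoromethyl in place of hydrogen on an aromatic carbon. Among the measured compounds shown here, no measured step adds a trifluoromethyl to a ring that already carries one; the measured steps show only that a single trifluoromethyl on that ring yields a readable number where chloro or sulfamoyl yield none. The step of a 1.6-fold lower number from compound 3 to compound 4 (0.20 log units; within the scatter) is therefore expected to stay within the scatter or bring a small lowering. Compound 4 is estimated at 1200 nM, between 400 nM and 4000 nM.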

Compound 4, half-maximal inhibitory concentration: 1900 nM
The estimate for compound 4 lay 1.6-fold (0.20 log units) below the measured number; low and high end bracket the measured number.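

The new step in this assay is no change at the digits printed from compound 3 to compound 4 (within the scatter) and so a second trifluoromethyl, meta to a trifluoromethyl group on this six-membered aromatic ring, leaves the read-out where the first one stood. The earlier compounds shown here compared only whole aryl groups, 3-(trifluoromethyl)phenyl against 4-chlorophenyl and 4-sulfamoylphenyl, whereas this pair changes one substituent on a ring that already gives a readable number. At this position, the added trifluoromethyl therefore brings no readable gain or loss.

The compounds shown leave open whether an amine, a carboxylic acid or a methoxy group at this carbon would shift the number, and whether a phenyl ring with no trifluoromethyl would give a readable number at all. The steps involving compound 1 and compound 2 give no exact size: the limit of > 10000 nM in this assay, at which 2 of the 4 values shown sit.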